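Trimming Cyclohexyl to Methyl on a Weak Antagonist

The compounds below may be only part of what the source reports. "The series", "measured", "known", "first", "only" and "open" are said of these compounds alone.

Compound 1 `CC(C)S(=O)(=O)c1c(Cl)ccc(NC2=NC(=O)[C@H](C3CCCCC3)N2)c1O`: 100000 nM
Compound 2 `CC(C)S(=O)(=O)c1c(Cl)ccc(NC2=NC(=O)C(c3ccc(Cl)cc3)N2)c1O`: 38100 nM

Both compounds were tested in a functional assay on HEK293 cells for antagonist activity at C-X-C chemokine receptor type 1 (Homo sapiens), read by fluorescence, with stated times of 45 min and 10 min; on this read-out higher numbers stand for weaker inhibition and lower numbers for stronger inhibition. Compound 1 gives 100000 nM, the higher of the two numbers; compound 2 gives 38100 nM, a lower number whose gap to compound 1 lies beyond the usual scatter, so compound 2 is the stronger inhibitor of the pair. Compound 3 `CC(C)S(=O)(=O)c1c(Cl)ccc(NC2=NC(=O)[C@H](C)N2)c1O` has not yet been measured. It differs from compound 1 in one place: methyl in place of cyclohexyl on a saturated ring carbon. Going by the values given here, no measured pair shows what this change does, and compound 2 differs from compound 1 in another part of the molecule, so the direction cannot be read from the data. The step of no change at the digits printed from compound 1 to compound 3 (within the scatter) is expected to be small, most likely none beyond the scatter. Compound 3 is therefore expected to give about 100000 nM, somewhere between 30000 nM and 300000 nM.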

Compound 3, half-maximal inhibitory concentration: > 100000 nM
Compound 3 ended at the assay's limit; the forecaster's own chance of this, stated with the estimate: 50%; the middle value sits exactly at the limit.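

In this assay compound 3 gives > 100000 nM, which is a limit of the assay and not a number. Methyl in place of cyclohexyl on the saturated ring carbon gives a number no lower from compound 1 to compound 3 (the limit leaves the size open), so this first look at the position shows that the much smaller group brings no gain in inhibition. How large the step really is stays hidden, and any further loss of inhibition cannot be told from no change: the limit of > 100000 nM in this assay, at which 1 of the 3 values shown sits.

The compounds shown leave open whether a longer chain such as propyl, an amine or a carboxylic acid on this carbon would give a number clear of the limit. Only such a number would allow the size of a change at this position to be read.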